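Swapping the bicyclic amide group on a dodecyl chain

The source may hold more compounds than are shown below. What is called first, only, known or untested is meant among the compounds shown, and "the series" means these compounds.

Compound 3 `CCCCCCCCCCCCNC(=O)[C@@H](NC(=O)c1cc2ccccc2o1)[C@@H](C)O` is one of three amides of a shared core examined in a functional assay on HepG2 cells (Homo sapiens) for cytotoxicity, read by MTT assay, with a stated time of 48 h; on this read-out higher numbers stand for weaker inhibition and lower numbers for stronger inhibition. In this assay compound 3 gives 22900 nM, the lowest of the two numbers obtained; the nearest is compound 1 `CCCCCCCCNC(=O)[C@@H](NC(=O)c1nccc2ccccc12)[C@@H](C)O`, which in this assay gives 88200 nM. Compound 2 `CCCCCCCCCCCCNC(=O)[C@@H](NC(=O)c1ccccc1)[C@@H](C)O` reaches only the limit of > 400000 nM in this assay. Among the compounds with values here, the one step that can be followed is an at least 17-fold lower number from compound 2 to compound 3 (1.24 log units; beyond the scatter); it rests on (the limit of > 400000 nM in this assay, at which 1 of the 3 values shown sits), so only its lower bound is known.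

Compound 4 `CCCCCCCCCCCCNC(=O)[C@@H](NC(=O)c1nccc2ccccc12)[C@@H](C)O` is not yet measured. It differs from compound 3 in one place: isoquinolin-1-yl in place of 1-benzofuran-2-yl on a carbonyl carbon. Within the data shown here, no measured step exchanges a 1-benzofuran-2-yl for an isoquinolin-1-yl, so this change cannot be calibrated directly. What the numbers do show is that compound 1, which also carries isoquinolin-1-yl on the carbonyl carbon but a shorter alkyl chain, sits at a higher number than compound 3. Compound 2 shows that a phenyl on that carbonyl carbon leaves the number at the limit. Both bicyclic groups thus give a measurable number. The step from compound 3 to compound 4 is expected to be modest, a 1.7-fold higher number from compound 3 to compound 4 (0.24 log units; within the scatter). Compound 4 is therefore estimated at 40000 nM, with a range from 12000 nM to 150000 nM.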

Compound 4, half-maximal inhibitory concentration: 65700 nM
Estimate against measurement, compound 4: 1.6-fold (0.22 log units) below; the range from low to high includes it.
By their numbers in this assay, from the lowest: compound 3; then compounds 4 and 1 (each within the scatter of the next). At a limit, above all of these: compound 2.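

In this assay, the two bicyclic groups on the carbonyl carbon of the dodecyl amide are not equivalent: isoquinolin-1-yl in place of 1-benzofuran-2-yl gives a 2.9-fold higher number from compound 3 to compound 4 (0.46 log units; beyond the scatter), while isoquinolin-1-yl in place of phenyl still gives an at least 6.0-fold lower number from compound 2 to compound 4 (0.78 log units; beyond the scatter). That second step is only a bound, because compound 2 stands at a limit: the limit of > 400000 nM in this assay, at which 1 of the 4 values shown sits. Butyl in place of hydrogen on a saturated chain carbon, eight bonds along the chain from an amide-type nitrogen, gives a 1.3-fold lower number from compound 1 to compound 4 (0.13 log units; within the scatter), so with isoquinolin-1-yl on the carbonyl carbon this change in the chain does not separate the two compounds.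

The compounds shown leave open how the same change in the chain reads with 1-benzofuran-2-yl or phenyl on the carbonyl carbon. They also leave open how an indol-2-yl group on that carbonyl carbon, or a longer chain or one ending in a carboxylic acid, would stand in this assay.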